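The source may hold more compounds than are shown below. What is called first, only, known or untested is meant among the compounds shown, and "the series" means these compounds.

Of the compounds shown here, three sharing one core have been measured in an in vivo ADME assay on the whole organism for pharmacokinetics, with Rattus norvegicus as the target, at a dose of 5 mg/kg by the oral route; a lower number here means that a smaller share of the oral dose reaches the circulation, a higher number that a larger share of the oral dose reaches the circulation. Compound 2 (`Cc1ccc([C@H](C(=O)N(C)C)N2C(=O)[C@@H](C3Cc4ccccc4C3)NC(=O)[C@H]2CC(C)C)cn1`) gives 57% and compound 1 (`CCC(CC)[C@@H]1C(=O)N[C@H](C2Cc3ccccc3C2)C(=O)N1[C@@H](C(=O)N1CCOCC1)c1ccc(C)nc1`) gives 55%, two values within the scatter of each other. Compound 3 (`Cc1ccc([C@H](C(=O)N2CCCC2)N2C(=O)[C@@H](C3Cc4ccccc4C3)NC(=O)[C@H]2CC(C)C)cn1`) gives 36%, which lies beyond the scatter from compound 2.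

Compound 4 (`CCC(CC)[C@@H]1C(=O)N[C@H](C2Cc3ccccc3C2)C(=O)N1[C@@H](C(=O)N(C)C)c1ccc(C)nc1`) differs from compound 2 at one place, with pentan-3-yl in place of isobutyl on a saturated ring carbon. Among the measured compounds shown here, no measured step covers this exact change. For the measured compounds named here, the only measured step, a number 21 percentage points lower from compound 2 to compound 3 (beyond the scatter), is pyrrolidin-1-yl in place of dimethylamino on a carbonyl carbon, so it bears on a different place and gives only a sense of how far this series can move. Compound 1 already carries pentan-3-yl, with a different group on the carbonyl, and gives 55%. On that evidence, no change beyond the scatter is expected, and the expected step is no change at the digits printed from compound 2 to compound 4 (within the scatter). Compound 4 is estimated at 57%, with an expected range from 40% to 74%.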

Compound 4, oral bioavailability: 36%
Beside the measured number, compound 4's estimate is 21 percentage points above it, and the stated range ends above it.
By their numbers in this assay, from the lowest: compounds 3 and 4 (each within the scatter of the next); then compounds 1 and 2 (each within the scatter of the next).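

In this assay, the saturated ring carbon proves to be a position where the choice of alkyl group counts: with dimethylamino kept on the carbonyl, pentan-3-yl in place of isobutyl gives a number 21 percentage points lower from compound 2 to compound 4 (beyond the scatter) and thus a step as large as any seen so far. Pentan-3-yl does not by itself fix a low number, since with it held in place, dimethylamino in place of morpholin-4-yl gives a number 19 percentage points lower from compound 1 to compound 4 (beyond the scatter), so the two places cannot be judged apart from each other. Nothing available gives a reason for either step.

The compounds shown leave open how a cyclopentyl or tert-butyl group would behave on that ring carbon. They also leave open whether isobutyl paired with morpholin-4-yl, or an azetidin-1-yl group on the carbonyl, would follow the same trend.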